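Hydroxy for Methyl on the Ring Nitrogen

The source may report more compounds than this note shows. Statements on the series, on what has been measured and on what is new or still open speak of the compounds shown alone.

Compound 1 `CN1C(=O)c2ccccc2C(C(=O)NCc2ccc(F)cc2)C1=O` was tested in an ADME assay on MT4 cells (Homo sapiens) for cytotoxicity, read by MTT assay; a lower number here means that less compound is tolerated, a higher number that more compound is tolerated. In this assay compound 1 gives only > 250000 nM, which is a limit of the assay and not a measured number. Among the compounds with values here, the other compound already measured, compound 2 `O=C(Nc1ccccc1)C1C(=O)N(O)C(=O)c2ccccc21`, gives 106000 nM in this assay; it carries a hydroxy on the ring nitrogen and an anilide instead of a benzyl amide, so it differs from compound 1 in more than one place and no single step joins the two.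

The compound still to be measured is compound 3 `O=C(NCc1ccc(F)cc1)C1C(=O)N(O)C(=O)c2ccccc21`. It differs from compound 1 in one place: hydroxy in place of methyl on an amide-type nitrogen in a ring. Within the data shown here, with no measured step of this kind to lean on, the two known values suggest that both cores are tolerated at high concentration, and only a modest shift, if any beyond the usual scatter, is anticipated.

Compound 3 is expected to give about 160000 nM in this assay, with a likely range from 60000 nM to 300000 nM. The expected step of an at least 1.5-fold lower number from compound 1 to compound 3 (0.19 log units; that floor lies within the scatter) is small, and since compound 1 sits at the limit of > 250000 nM in this assay, at which 1 of the 2 values shown sits, the new measurement may again return only a limit.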

Compound 3, half-maximal cytotoxic concentration: 202000 nM
For compound 3 the middle estimate is 1.3-fold (0.10 log units) below the measured one; measured number inside the range.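

Within the data shown here, compound 3 gives the first reading for the change from methyl to hydroxy on this ring nitrogen with the rest of the molecule held fixed, and in this assay that change amounts to an at least 1.2-fold lower number from compound 1 to compound 3 (0.09 log units; that floor lies within the scatter) in a compound that still has the 4-fluorobenzyl amide. On these data alone, for compound 1 the reading of > 250000 nM is a limit of the assay and not a number, so the step has only a floor and its true size stays unknown, with the ceiling of the assay close to all the values here: the limit of > 250000 nM in this assay, at which 1 of the 3 values shown sits. Compound 3 also provides a one-place link on the hydroxy core, where 4-fluorobenzyl in place of phenyl on the amide nitrogen gives a 1.9-fold higher number from compound 2 to compound 3 (0.28 log units; within the scatter) and so cannot be told apart from repeat-to-repeat variation.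

The compounds shown carry only methyl or hydroxy on the ring nitrogen, so it remains open how an amine or a longer chain such as ethyl at this place would read. As far as these compounds go, it also remains open whether the hydroxy compounds and compound 1 would separate at all if the assay could read beyond its limit.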